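This account rests on a few compounds, and the source may have more. Where it says the series, first, only, none or still open, it means among the compounds named here.

Compound 1 `N#CC(/C=C/[C@@H](O)C[C@@H](O)CC(=O)O)=C(c1ccc(F)cc1)c1ccc(F)cc1` carries a nitrile on the shared core, and in an assay for inhibition of 3-hydroxy-3-methylglutaryl-coenzyme A reductase (Rattus norvegicus) (on this read-out lower numbers stand for stronger inhibition and higher numbers for weaker inhibition), compound 1 gives 8000 nM. Compound 2 `Cn1nnnc1C(C=C=C[C@@H](O)C[C@@H](O)CC(=O)O)=C(c1ccc(F)cc1)c1ccc(F)cc1` carries instead a 1-methyl-1H-tetrazol-5-yl group, and in this assay compound 2 gives 5700 nM. On these two numbers compound 2 stands alongside compound 1; the gap between them lies within the scatter, so the two cannot be ranked against each other. Compound 3 `CC(C)n1nnnc1C(C=C=C[C@@H](O)C[C@@H](O)CC(=O)O)=C(c1ccc(F)cc1)c1ccc(F)cc1` has not been measured; it differs from compound 2 in one place, (isopropyl in place of methyl on an aromatic nitrogen), isopropyl in place of methyl on an aromatic nitrogen. Within the data shown here, no measured pair shows this step, so its size can only be guessed from the change itself. A modest move toward a smaller number in this assay is expected, a 2.3-fold lower number from compound 2 to compound 3 (0.36 log units; beyond the scatter), with real room for no change beyond the scatter. Compound 3 is accordingly estimated at 2500 nM, with a range from 800 nM to 8000 nM.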

Compound 3, half-maximal inhibitory concentration: 130000 nM
Compound 3: the middle estimate sits 52-fold (1.72 log units) below what was measured, and the stated range ends below it.
By their numbers in this assay, from the lowest: compounds 2 and 1 (each within the scatter of the next); then compound 3.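

At this position the change is far from neutral: in this assay, isopropyl in place of methyl on an aromatic nitrogen gives a 23-fold higher number from compound 2 to compound 3 (1.36 log units; beyond the scatter). Among these compounds, this is the first step that can be read at this position, and it shows that a small alkyl change on the nitrogen of the 1-methyl-1H-tetrazol-5-yl group can weaken inhibition sharply. Nothing measured here accounts for the size of this step.

The compounds shown leave open whether ethyl on the same nitrogen would fall nearer to compound 2 or to compound 3, and so whether the loss follows the added carbons or the branching, which n-propyl could also help to separate. They also leave open whether hydrogen at this nitrogen would give a lower number than methyl in this assay.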